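Estimating the cytotoxicity of a naphthalen-1-yl analogue

The source may report more compounds than this note shows. Statements on the series, on what has been measured and on what is new or still open speak of the compounds shown alone.

Values in an ADME assay on MT4 cells (Homo sapiens) for cytotoxicity, read by MTT assay; on this read-out higher numbers stand for lower toxicity in this test and lower numbers for higher toxicity in this test:
- Compound 1 `O=C1c2ccccc2C(=O)N1CCOC(=S)N(C(=O)c1cccc(F)c1F)c1ccc(Cl)cc1`: 58000 nM
- Compound 2 `O=C1c2ccccc2C(=O)N1CCOC(=S)N(C(=O)c1ccc(Cl)c(Cl)c1)c1ccc(Cl)cc1`: 35000 nM
- Compound 3 `O=C1c2ccccc2C(=O)N1CCOC(=S)N(C(=O)c1cccc2ccccc12)c1ccc(Cl)cc1`: not yet measured

Compound 2 gives 35000 nM, which lies within the scatter of compound 1, so the two cannot be ranked. Compound 3 carries naphthalen-1-yl in place of 3,4-dichlorophenyl on a carbonyl carbon. Among the measured compounds shown here, only one measured step bears on this change, a swap at the same place: a 1.7-fold lower number from compound 1 to compound 2 (0.22 log units; within the scatter). One small step is thin evidence, and it gives no direction, so no change beyond the scatter is expected in this assay. The expected change is a 1.1-fold higher number from compound 2 to compound 3 (0.06 log units; within the scatter). Compound 3 is estimated at 40000 nM, with an expected range of 17000 nM to 90000 nM.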

Compound 3, half-maximal cytotoxic concentration: 6000 nM
For compound 3 the middle estimate is 6.7-fold (0.82 log units) above the measured one, and the stated range ends above it.
By their numbers in this assay, from the lowest: compound 3; then compounds 2 and 1 (each within the scatter of the next).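

In this assay, the group on this carbonyl carbon proves able to shift the read-out: naphthalen-1-yl in place of 3,4-dichlorophenyl gives a 5.8-fold lower number from compound 2 to compound 3 (0.77 log units; beyond the scatter), and in place of 2,3-difluorophenyl it gives a 9.7-fold lower number from compound 1 to compound 3 (0.99 log units; beyond the scatter). Both steps lie beyond the scatter, so this group with 2 aromatic rings goes with higher toxicity in this test, whereas the two groups with one ring could not be separated. No measurement here accounts for the change. Going by these compounds, it remains open whether naphthalen-2-yl, an unsubstituted phenyl or a pyridyl ring would give a similar number.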